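Replacing a dimethylimidazole with a tetrazole

The source may report more compounds than this note shows. Statements on the series, on what has been measured and on what is new or still open speak of the compounds shown alone.

- compound 1 `CCC(C)n1ncn(-c2ccc(N3CCN(c4ccc(OC[C@@H]5CO[C@@](Cn6ccnc6-c6ccccc6)(c6ccc(Cl)cc6Cl)O5)cc4)CC3)cc2)c1=O`: 136 nM
- compound 2 `CCC(C)n1ncn(-c2ccc(N3CCN(c4ccc(OC[C@@H]5CO[C@@](Cn6c(C)cnc6C)(c6ccc(Cl)cc6Cl)O5)cc4)CC3)cc2)c1=O`: 765 nM

Both values come from a functional assay on HUVEC cells (Homo sapiens), read by scintillation counting and thymidine incorporation, with a stated time of 24 h; a higher number here means a weaker inhibitor, a lower number a stronger inhibitor. Compound 2, at 765 nM, has the higher of the two numbers and is thus the weaker inhibitor of the pair.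

Compound 3 `CCC(C)n1ncn(-c2ccc(N3CCN(c4ccc(OC[C@@H]5CO[C@@](Cn6ncnn6)(c6ccc(Cl)cc6Cl)O5)cc4)CC3)cc2)c1=O` has not yet been measured. It carries 2H-tetrazol-2-yl in place of 2,5-dimethyl-1H-imidazol-1-yl on a saturated chain carbon bound to a saturated ring carbon.

Within the data shown here, one measured step bears on this change, as it falls at the same place: a 5.6-fold higher number from compound 1 to compound 2 (0.75 log units; beyond the scatter). It shows that the number in this assay can move beyond the scatter when this group changes. Among the measured compounds shown here, that step involves a different pair of groups, however, and no measured compound carries 2H-tetrazol-2-yl, so the direction remains uncertain. A step of similar or smaller size is expected, leaning tentatively towards a lower number.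

The estimate amounts to an expected 1.7-fold lower number from compound 2 to compound 3 (0.23 log units; within the scatter). For compound 3 the expected value is 450 nM, with an estimated range of 130 nM to 1500 nM.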

Compound 3, half-maximal inhibitory concentration: 124 nM
Beside the measured number, compound 3's estimate is 3.6-fold (0.56 log units) above it; measured number below the stated range.
By their numbers in this assay, from the lowest: compounds 3 and 1 (each within the scatter of the next); then compound 2.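

In this assay the place on a saturated chain carbon bound to a saturated ring carbon proves able to recover from the rise seen with 2,5-dimethyl-1H-imidazol-1-yl: 2H-tetrazol-2-yl gives a 6.2-fold lower number from compound 2 to compound 3 (0.79 log units; beyond the scatter) and so reverses a change of about the same size, a 5.6-fold higher number from compound 1 to compound 2 (0.75 log units; beyond the scatter) in the opposite direction. The phenyl of 2-phenyl-1H-imidazol-1-yl is not required for the lower numbers among these compounds, as the comparison with the tetrazole shows a 1.1-fold lower number from compound 1 to compound 3 (0.04 log units; within the scatter) and leaves compound 1 and compound 3 within the scatter of each other. Of the three groups, it is therefore 2,5-dimethyl-1H-imidazol-1-yl in compound 2 that stands apart, while two quite different rings, one bearing a phenyl and one with 4 nitrogen atoms, give matching numbers.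

As far as these compounds go, whether an unsubstituted imidazole, a 1,2,4-triazole or the 1H-tetrazol-1-yl isomer at this place would fall with compound 1 and compound 3 or with compound 2 remains open, as does the effect of a single methyl on the imidazole. Nothing measured alongside these numbers accounts for their movement at this place.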